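Methyl to propyl in a small series

The source may hold more compounds than are shown below. What is called first, only, known or untested is meant among the compounds shown, and "the series" means these compounds.

In an ADME assay for lipophilicity (on this read-out lower numbers stand for lower lipophilicity and higher numbers for higher lipophilicity), compound 1 `COCc1cc(=O)c(O)co1` stands at -0.62 and compound 2 `Cc1cc(=O)c(O)c(C)o1` stands at 0.44 on the same scale, which makes compound 2 the higher of the two numbers, with the gap beyond the scatter. Compound 3 `CCCc1oc(C)cc(=O)c1O` awaits measurement in this assay and differs from compound 2 by ethyl in place of hydrogen on a saturated chain carbon bound to an aromatic carbon in the form of ethyl in place of hydrogen on a saturated chain carbon bound to an aromatic carbon, the same difference reading as methyl to propyl. For the measured compounds named here, no measured step from a single change exists, so the expectation rests on the structural change alone. An upward move beyond the scatter is expected, with a number 0.91 log units higher from compound 2 to compound 3 (beyond the scatter) as the estimated size of the step. For compound 3 an estimated value of 1.35 is expected, within the range 0.95 to 1.75 once measured.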

Compound 3, distribution coefficient: 1.4
Beside the measured number, compound 3's estimate is 0.05 log units below it; the measured number falls inside the stated range.
By their numbers in this assay, from the lowest: compound 1; then compound 2; then compound 3.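

Working notes: in this assay, ethyl in place of hydrogen on a saturated chain carbon bound to an aromatic carbon, the same difference as methyl to propyl, gives a number 0.96 log units higher from compound 2 to compound 3 (beyond the scatter) and provides the only single-place step in this series. Compound 1 and compound 2 differ in more than one place, so their gap could not be tied to this position or to any one change. Nothing available accounts for the size of this step.

From the compounds shown here alone, one step at one position gives no trend, so whether a longer chain such as butyl would extend the rise in this assay remains open. Also open, going by these compounds, are a chain ending in an amine or a carboxylic acid at this position, and whether methyl to propyl gives a step of similar size on the core of compound 1.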